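Chloro for methyl on the aryl thiourea of compound 2

The source may hold more compounds than are shown below. What is called first, only, known or untested is meant among the compounds shown, and "the series" means these compounds.

In a functional assay on A549 cells (Homo sapiens) for inhibition, read by CCK-8 assay, with a stated time of 48 h (a higher number here means a weaker inhibitor, a lower number a stronger inhibitor), compound 1 `Cc1ccc(NC(=S)NC(=O)c2cn(-c3ccccc3)nc2-c2ccc(F)cc2)cc1` gives 2080 nM, and compound 2 `Cc1ccc(NC(=S)NC(=O)c2cn(-c3ccccc3)nc2-c2ccccc2)cc1` gives 2800 nM. For the measured compounds named here, compound 2 has the higher of the two numbers, but its only neighbour, compound 1, sits within the scatter, so the two cannot be ranked; the step of a 1.3-fold higher number from compound 1 to compound 2 (0.13 log units; within the scatter) is likewise within the scatter. Compound 3 `O=C(NC(=S)Nc1ccc(Cl)cc1)c1cn(-c2ccccc2)nc1-c1ccccc1` differs from compound 2 by chloro in place of methyl on an aromatic carbon. Going by the values given here, the single measured step concerns a different ring of the shared core and a different exchange, so it offers no direct guide to this one; it only shows that a small change on an aromatic carbon left this assay unmoved. With nothing else to go on, no step beyond the scatter is expected from compound 2 to compound 3, that is no change at the digits printed from compound 2 to compound 3 (within the scatter). Compound 3 is therefore estimated at 2800 nM, with a range from 1200 nM to 6500 nM.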

Compound 3, half-maximal inhibitory concentration: 3200 nM
Compound 3: middle estimate off by 1.1-fold (0.06 log units), on the low side; the range from low to high includes it.
By their numbers in this assay, from the lowest: compounds 1, 2 and 3 (each within the scatter of the next).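

For the compounds shown here, compound 2 and compound 3 are the first pair to probe the 4-methylphenyl group on the thiourea, and in this assay the exchange to 4-chlorophenyl gives a 1.1-fold higher number from compound 2 to compound 3 (0.06 log units; within the scatter) and leaves the two compounds unranked. Together with the earlier step, this shows that a swap of one heavy atom on this ring, para to a large group, is as silent in this assay as the hydrogen for fluoro exchange on the other aryl ring. No measurement is available that bears on the reason for this result.

Going by these compounds, whether an amine, a carboxylic acid or a longer chain at this same position would move the number beyond the scatter remains open. So does whether chloro here would read the same on the fluoro-bearing core of compound 1.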